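One more chain carbon, from compound 3 to compound 4

The source may hold more compounds than are shown below. What is called first, only, known or untested is meant among the compounds shown, and "the series" means these compounds.

Values in a functional assay on NCI-H460 cells (Homo sapiens) for antiproliferative activity, read by MTT assay, with a stated time of 48 h; on this read-out higher numbers stand for weaker inhibition and lower numbers for stronger inhibition:
- compound 1 `CCCCCCC1(O)C(=O)Nc2ccc(Nc3ccc(C)cc3)cc21` gives > 100000 nM (a limit, not a number)
- compound 2 `CCCCC1(O)C(=O)Nc2ccc(Nc3ccc(Cl)cc3)cc21` gives 24400 nM
- compound 3 `CCCCCC1(O)C(=O)Nc2ccc(Nc3ccc(Cl)cc3)cc21` gives 40800 nM

Going by the values given here, compound 3 lies within the scatter of compound 2, and these two hold the only true numbers so far. Compound 4 `CCCCCCC1(O)C(=O)Nc2ccc(Nc3ccc(Cl)cc3)cc21` has methyl in place of hydrogen on a saturated chain carbon, five bonds along the chain from a saturated ring carbon. Among the compounds with values here, the one measured step of this kind, four bonds along the chain, is a 1.7-fold higher number from compound 2 to compound 3 (0.22 log units; within the scatter) and offers the only guide. In this assay the expected step is therefore a 1.2-fold higher number from compound 3 to compound 4 (0.09 log units; within the scatter) and nothing beyond the scatter is expected. Compound 4 is estimated at 50000 nM (expected range 25000 nM to 100000 nM).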

Compound 4, half-maximal inhibitory concentration: 30300 nM
Beside the measured number, compound 4's estimate is 1.7-fold (0.22 log units) above it; the range from low to high includes it.
By their numbers in this assay, from the lowest: compounds 2, 4 and 3 (each within the scatter of the next). At a limit, above all of these: compound 1.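

In this assay, methyl in place of hydrogen at this far chain carbon gives a 1.3-fold lower number from compound 3 to compound 4 (0.13 log units; within the scatter), and ethyl in place of hydrogen gives a 1.2-fold higher number from compound 2 to compound 4 (0.09 log units; within the scatter), so none of the three chain lengths carrying chloro stands apart from the others. Chloro in place of methyl on the aromatic carbon gives an at least 3.3-fold lower number from compound 1 to compound 4 (0.51 log units; beyond the scatter), the only step here beyond the scatter. That step rests on a limit for compound 1, not a number: the limit of > 100000 nM in this assay, at which 1 of the 4 values shown sits.

Still open, going by these compounds, is whether a longer chain keeps the numbers this close. Also open, on these data alone, is whether an amine or a carboxylic acid on the chain would move them.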